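Ring-Closed Urea in Place of an Open Amide

The source may hold more compounds than are shown below. What is called first, only, known or untested is meant among the compounds shown, and "the series" means these compounds.

Going by the values given here, compound 2 `COCC(=O)NC1CCN(c2nc(C)c3cc(NC(=O)/C=C/c4ccc(OC(F)(F)F)cc4)ccc3n2)CC1` gives 14 nM in a functional assay on CHO-K1 cells for antagonist activity at melanin-concentrating hormone receptor 1 (Homo sapiens), read by inositol phosphate accumulation, with stated times of 10 min and 45 min (a higher number here means a weaker inhibitor, a lower number a stronger inhibitor), the lowest of the two numbers measured so far; compound 1 `Cc1nc(N2CCC(NS(=O)(=O)N(C)C)CC2)nc2ccc(NC(=O)/C=C/c3ccc(OC(F)(F)F)cc3)cc12` gives 31 nM. Among the compounds with values here, the only measured step, a 2.2-fold lower number from compound 1 to compound 2 (0.35 log units; beyond the scatter), exchanged one group on that same amine nitrogen. Compound 3 `Cc1nc(N2CCC(N3CCNC3=O)CC2)nc2ccc(NC(=O)/C=C/c3ccc(OC(F)(F)F)cc3)cc12` carries the change (2-oxoimidazolidin-1-yl in place of ((methoxymethyl)carbonyl)amino on a saturated ring carbon). The earlier step is only a loose guide: here the nitrogen itself becomes part of a ring. The expected step from compound 2 to compound 3, a 1.4-fold higher number from compound 2 to compound 3 (0.15 log units; within the scatter), is therefore small, without a direction claimed beyond the scatter. Compound 3 is expected near 20 nM, within 7 nM to 60 nM.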

Compound 3, half-maximal inhibitory concentration: 31 nM
Compound 3: middle estimate off by 1.6-fold (0.19 log units), on the low side; low and high end bracket the measured number.
By their numbers in this assay, from the lowest: compound 2; then compounds 1 and 3 (each within the scatter of the next).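

On this saturated ring carbon, the 2-oxoimidazolidin-1-yl ring does not match the open ((methoxymethyl)carbonyl)amino group, giving a 2.2-fold higher number from compound 2 to compound 3 (0.35 log units; beyond the scatter). Against (dimethylsulfamoyl)amino, the same ring shows no change at the digits printed from compound 1 to compound 3 (within the scatter), so of these three groups only ((methoxymethyl)carbonyl)amino stands apart. Nothing available here explains why the open group gives the lower number. Still open, on these data alone, is whether the methoxymethyl part matters, which a plain acetyl group on the same amine nitrogen could test. As far as these compounds go, how a 2-oxooxazolidin-3-yl ring on that carbon would compare also remains unknown.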